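This account rests on a few compounds, and the source may have more. Where it says the series, first, only, none or still open, it means among the compounds named here.

Measured so far:
- Compound 1 `CC1(C)CCc2c(ccc(C(=O)/C=C/c3ccc(OCc4cn(-c5ccc(Br)cc5)nn4)cc3)c2O)O1`: 136000 nM
- Compound 2 `COc1ccc(-n2cc(COc3ccc(/C=C/C(=O)c4ccc5c(c4O)CCC(C)(C)O5)cc3)nn2)c([N+](=O)[O-])c1`: 120000 nM
- Compound 3 `CC(=O)c1ccc(-n2cc(COc3ccc(/C=C/C(=O)c4ccc5c(c4O)CCC(C)(C)O5)cc3)nn2)cc1`: 91400 nM

In a functional assay on HepG2 cells (Homo sapiens) for antiproliferative activity, read by MTT assay (on this read-out higher numbers stand for weaker inhibition and lower numbers for stronger inhibition), compound 3 gives 91400 nM, and this value cannot be separated from those of the other two compounds. Compound 4 `Cc1ccc(-n2cc(COc3ccc(/C=C/C(=O)c4ccc5c(c4O)CCC(C)(C)O5)cc3)nn2)cc1Br` has not yet been measured. It carries 3-bromo-4-methylphenyl in place of 4-acetylphenyl on an aromatic nitrogen of the five-membered ring: 3-bromo-4-methylphenyl in place of 4-acetylphenyl on an aromatic nitrogen.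

For the measured compounds named here, three measured steps bear on this change. The closest is a 1.5-fold lower number from compound 1 to compound 3 (0.17 log units; within the scatter), where acetyl replaces bromo on an aromatic carbon, since compound 1 also carries a bromine on its phenyl group. The whole-group exchanges on the same nitrogen are a 1.1-fold lower number from compound 1 to compound 2 (0.05 log units; within the scatter) and a 1.3-fold lower number from compound 2 to compound 3 (0.12 log units; within the scatter). All three steps stay within the scatter, so swapping this group has so far not moved this assay measurably across these compounds. Three compounds are a thin basis, and none of them carries the methyl group, so the expectation is only tentative.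

The expected step is a 1.1-fold higher number from compound 3 to compound 4 (0.06 log units; within the scatter), and no change beyond the scatter is anticipated. For compound 4 the estimated value is 105000 nM, with an expected range from 60000 nM to 180000 nM.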

Compound 4, half-maximal inhibitory concentration: 110000 nM
The estimate for compound 4 lay 1.0-fold (0.02 log units) below the measured number; low and high end bracket the measured number.
By their numbers in this assay, from the lowest: compounds 3, 4, 2 and 1 (each within the scatter of the next).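

In this assay putting 3-bromo-4-methylphenyl on the aromatic nitrogen gives a 1.2-fold higher number from compound 3 to compound 4 (0.08 log units; within the scatter) and a 1.1-fold lower number from compound 2 to compound 4 (0.04 log units; within the scatter) and a 1.2-fold lower number from compound 1 to compound 4 (0.09 log units; within the scatter) so this fourth substituted phenyl group cannot be separated from any of the other three. The result extends the flat picture to a phenyl group bearing both a bromine and a methyl group, and the exchange for 4-acetylphenyl, which trades a group with a hydrogen-bond acceptor for one without, also stays within the scatter. No measurement at hand offers an explanation for this lack of separation.

Going by these compounds, all four compounds keep a substituted phenyl group on this nitrogen, so it remains open whether an amine, a carboxylic acid or a longer chain in its place would shift this assay beyond the scatter. On these data alone, it also remains open whether a change elsewhere on the shared core, such as replacing the hydroxyl group or the carbonyl, would separate compounds that this position does not.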